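A few compounds are considered here, and "the series" means these few. Any claim that something is new, unique, unknown or untested is made for them only; others in the source may bear on it.

Measured compounds in this series:

compound 1, `Cn1c(=O)c(S(=O)(=O)c2ccc(F)cc2)cc2cnc(Nc3ccc4occc4c3)nc21`, 5000 nM
compound 2, `Cn1c(=O)c(S(=O)(=O)c2ccc(F)cc2F)cc2cnc(Nc3ccc4occc4c3)nc21`, 15000 nM
compound 3, `CN1CCN(c2ccc(Nc3ncc4cc(S(=O)(=O)c5ccc(F)cc5F)c(=O)n(C)c4n3)cc2)CC1`, 5000 nM

In a functional assay on DU-145 cells (Homo sapiens) for inhibition, read by trypan blue exclusion, with a stated time of 72 h (a higher number here means a weaker inhibitor, a lower number a stronger inhibitor), compound 2 gives the highest number of the three, standing apart from compound 1 by a 3.0-fold higher number from compound 1 to compound 2 (0.48 log units; beyond the scatter); compound 3 gives 5000 nM, which is the same number as compound 1 and likewise lower than the value of compound 2. Compound 4, `Cn1c(=O)c(S(=O)(=O)c2ccc(F)cc2F)cc2cnc(Nc3ccccn3)nc21`, has not yet been measured. It differs from compound 2 at the aminoaryl substituent: pyridin-2-yl in place of 1-benzofuran-5-yl on a nitrogen on an aromatic ring. For the measured compounds named here, the one step that has been measured, from compound 1 to compound 2, concerns a fluoro in place of hydrogen on a sulfonyl aryl ring and so does not touch the site changed here. Going by the values given here, compounds 2 and 3 differ at that site, and their two values show that an exchange there can move the number, but no step for the pyridin-2-yl group itself is available. With only that to go on, compound 4 is expected to remain near or somewhat beyond compound 2, and the step is estimated as a 1.3-fold higher number from compound 2 to compound 4 (0.12 log units; within the scatter) in this assay. Compound 4 is therefore expected to give about 20000 nM in this assay, within a range of 5000 nM to 80000 nM.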

Compound 4, half-maximal inhibitory concentration: 75000 nM
Beside the measured number, compound 4's estimate is 3.8-fold (0.57 log units) below it; measured number inside the range.
By their numbers in this assay, from the lowest: compounds 1 and 3 (each within the scatter of the next); then compound 2; then compound 4.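

In this assay, pyridin-2-yl in place of 1-benzofuran-5-yl on the nitrogen gives a 5.0-fold higher number from compound 2 to compound 4 (0.70 log units; beyond the scatter), the first step read directly at this position and one that lies beyond the scatter. The earlier step concerned a fluoro on the sulfonyl aryl ring, whereas this one shows that the number also responds to the aminoaryl group, and that a single six-membered aromatic ring with one hetero atom, replacing a fused pair of five- and six-membered aromatic rings, leaves compound 4 with the highest number of the four. Nothing given here accounts for this step.

As far as these compounds go, whether a plain phenyl on this nitrogen would read nearer compound 2 or compound 4 stays open, and with it whether the step follows the loss of the five-membered ring or the entry of the ring nitrogen. Also open, from the compounds shown here alone, is how an amine carried on the pyridin-2-yl would read; with another group at this same place, compound 3 gives 5000 nM.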